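Amide variation at the carbonyl of the benzofuran series

The compounds below may be only part of what the source reports. "The series", "measured", "known", "first", "only" and "open" are said of these compounds alone.

Among the compounds with values here, compound 2 `Cc1c(C(=O)N(C)C)oc2ccc(Nc3ncnc4ccc(Cl)nc34)cc12` gives 2200 nM in an assay on isolated protein for inhibition of MAP kinase-interacting serine/threonine-protein kinase 2 (Homo sapiens), read by HTRF, in the presence of a further agent that is not named here (on this read-out lower numbers stand for stronger inhibition and higher numbers for weaker inhibition), and stands lowest of the two numbers so far; compound 1 `COC(=O)c1oc2ccc(Nc3ncnc4ccc(Cl)nc34)cc2c1C` gives 4800 nM in this assay. Within the data shown here, the only step at this carbonyl, a 2.2-fold lower number from compound 1 to compound 2 (0.34 log units; beyond the scatter), turned methoxy into dimethylamino. Compound 3 `CCCNC(=O)c1oc2ccc(Nc3ncnc4ccc(Cl)nc34)cc2c1C` carries propylamino in place of dimethylamino on a carbonyl carbon. Among the measured compounds shown here, no measured pair shows the same change, so the one step above bears on it only loosely, and the amide is kept. A step of roughly the same size or none beyond the scatter is expected for a 1.2-fold lower number from compound 2 to compound 3 (0.09 log units; within the scatter). Compound 3 is therefore estimated at 1800 nM in this assay, within 600 nM to 5000 nM.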

Compound 3, half-maximal inhibitory concentration: 1900 nM
Compound 3: middle estimate off by 1.1-fold (0.02 log units), on the low side, within the range that was stated.
By their numbers in this assay, from the lowest: compounds 3 and 2 (each within the scatter of the next); then compound 1.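

Propylamino in place of dimethylamino on the carbonyl carbon gives a 1.2-fold lower number from compound 2 to compound 3 (0.06 log units; within the scatter) in this assay, so this exchange of amines, which brings in a hydrogen-bond donor and one more heavy atom, does not separate the two amides. Propylamino in place of methoxy gives a 2.5-fold lower number from compound 1 to compound 3 (0.40 log units; beyond the scatter), so both amides now stand beyond the scatter from the ester, and no compound shown goes against this.

Open, going by these compounds, is whether a longer chain, morpholine or a carboxylic acid on this carbonyl carbon would shift the number further. No evidence on the cause of these steps is at hand.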